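From Fluoro to Methyl on a Double-Bonded Chain Carbon

The source may report more compounds than this note shows. Statements on the series, on what has been measured and on what is new or still open speak of the compounds shown alone.

Three compounds share one core and differ only in the group on a carbonyl carbon: compound 1 `C/C=C/C(=O)Nc1cc(Nc2nccc(-c3cn(C)c4ccccc34)n2)c(OC)cc1N(C)CCN(C)C` carries prop-1-en-1-yl, compound 2 `C=C(C(=O)Nc1cc(Nc2nccc(-c3cn(C)c4ccccc34)n2)c(OC)cc1N(C)CCN(C)C)C(F)(F)F` carries 1-(trifluoromethyl)ethenyl, and compound 3 `C=C(F)C(=O)Nc1cc(Nc2nccc(-c3cn(C)c4ccccc34)n2)c(OC)cc1N(C)CCN(C)C` carries 1-fluoroethenyl. In a functional assay on NCI-H1975 cells (Homo sapiens) for antiproliferative activity, read by sulforhodamine B assay, with a stated time of 72 h (a lower number here means a stronger inhibitor, a higher number a weaker inhibitor), compound 1 gives 496 nM, compound 2 gives 546 nM and compound 3 gives 208 nM. Compound 3 therefore has the lowest number of the three.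

The next compound, compound 4 `C=C(C)C(=O)Nc1cc(Nc2nccc(-c3cn(C)c4ccccc34)n2)c(OC)cc1N(C)CCN(C)C`, has methyl in place of fluoro on a double-bonded chain carbon bound to a carbonyl carbon. Going by the values given here, no measured step makes this exact swap. The closest is a 2.6-fold lower number from compound 2 to compound 3 (0.42 log units; beyond the scatter), a change at the same place. A second comparison, a 2.4-fold lower number from compound 1 to compound 3 (0.38 log units; beyond the scatter), also ends at 1-fluoroethenyl and is of similar, modest size. By contrast, a 1.1-fold higher number from compound 1 to compound 2 (0.04 log units; within the scatter) shows that two groups without the fluoro can sit level with each other. Among the compounds with values here, only three compounds support this reading, but none goes against it, so a modest rise in this assay is expected on losing the fluoro. The expected change is a 2.2-fold higher number from compound 3 to compound 4 (0.34 log units; beyond the scatter). The estimate for compound 4 is 450 nM, within an expected range of 190 nM to 1100 nM.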

Compound 4, half-maximal inhibitory concentration: 486 nM
Estimate against measurement, compound 4: 1.1-fold (0.03 log units) below; the measured number falls inside the stated range.
By their numbers in this assay, from the lowest: compound 3; then compounds 4, 1 and 2 (each within the scatter of the next).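

In this assay the direct swap of fluoro for methyl on a double-bonded chain carbon bound to a carbonyl carbon gives a 2.3-fold higher number from compound 3 to compound 4 (0.37 log units; beyond the scatter), so the effect of this change is now measured rather than inferred from related changes at the same place. Methyl and trifluoromethyl at this place sit level, with a 1.1-fold lower number from compound 2 to compound 4 (0.05 log units; within the scatter), and the same holds for the two groups prop-1-en-1-yl and 1-methylethenyl, with a 1.0-fold lower number from compound 1 to compound 4 (0.01 log units; within the scatter). Going by these compounds alone, compound 3 is therefore the strongest inhibitor of the four in this assay, and 1-fluoroethenyl is the only one of these groups that stands apart, while the other three cannot be told from one another.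

Nothing in the data shown explains why fluoro alone stands apart. As far as these compounds go, it also remains open whether another small atom or group at this place, such as chloro or a nitrile, would match fluoro, and whether a chain carrying an amine, such as dimethylaminomethyl, would sit with fluoro or with the other three groups.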